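Swapping the sulfonyl aryl group on a benzyl sulfonamide

The source may hold more compounds than are shown below. What is called first, only, known or untested is meant among the compounds shown, and "the series" means these compounds.

Compound 3 `CCOC(=O)c1oc2ccc(N(Cc3ccccc3)S(=O)(=O)c3ccccc3Br)cc2c1C` sits at the bottom of the numbers in hand: in a functional assay on HCT-116 cells (Homo sapiens) for inhibition, read by MTT assay, with a stated time of 72 h (on this read-out higher numbers stand for weaker inhibition and lower numbers for stronger inhibition), compound 3 gives only the limit > 40000 nM, and the limit of > 40000 nM in this assay, at which 1 of the 3 values shown sits, shows this is the assay ceiling rather than a number. Among the measured compounds shown here, the measured comparisons come from compound 1 `CCOC(=O)c1oc2ccc(NS(=O)(=O)c3ccc(C(F)(F)F)cc3)cc2c1C`, which gives 5030 nM, and compound 2 `CCOC(=O)c1oc2ccc(NS(=O)(=O)c3ccc(F)cc3)cc2c1C`, which gives 10500 nM; the change a 2.1-fold higher number from compound 1 to compound 2 (0.32 log units; beyond the scatter) is the only step with a number on both sides. Compound 4 `CCOC(=O)c1oc2ccc(N(Cc3ccccc3)S(=O)(=O)c3ccc(Cl)cc3)cc2c1C` differs from compound 3 by 4-chlorophenyl in place of 2-bromophenyl on a sulfonyl sulfur. For the measured compounds named here, no measured step covers this change, since compounds 1 and 2 differ from compound 3 in more than one place, so compound 4 is expected near the ceiling, with a step of an at least 1.1-fold lower number from compound 3 to compound 4 (0.05 log units; that floor lies within the scatter) at most. Compound 4 is estimated at 35000 nM, between 8000 nM and 100000 nM.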

Compound 4, half-maximal inhibitory concentration: 4860 nM
Compound 4: middle estimate off by 7.2-fold (0.86 log units), on the high side, outside the stated range (below it).
By their numbers in this assay, from the lowest: compounds 4 and 1 (each within the scatter of the next); then compound 2. At a limit, above all of these: compound 3.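

Exchanging 2-bromophenyl for 4-chlorophenyl on the sulfonyl sulfur gives an at least 8.2-fold lower number from compound 3 to compound 4 (0.91 log units; beyond the scatter) in this assay. It shows that a compound with a benzyl group on the sulfonamide nitrogen can give a measured value, and that the sulfonyl aryl group matters at this position. The true size of the step stays unknown, because compound 3 carries a limit and not a number: the limit of > 40000 nM in this assay, at which 1 of the 4 values shown sits.

From the compounds shown here alone, it remains open whether the step follows the halogen or its place on the ring, which a 4-bromophenyl group on the same sulfur would separate. Going by these compounds, how an amine on that ring would read is also open.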